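This account rests on a few compounds, and the source may have more. Where it says the series, first, only, none or still open, it means among the compounds named here.

Compound 3 `CO[C@@H]1CC=C2N(c3ccc(C)cc3)C(=O)C[C@]2(c2ccccc2)O1` gives 3500 nM in a functional assay on SK-N-SH cells (Homo sapiens) for cytotoxicity, read by sulforhodamine B assay, with a stated time of 48 h; a lower number here means a stronger inhibitor, a higher number a weaker inhibitor. Among the three measured compounds it stands second highest: compound 2 `COc1cc(OC)cc(N2NC3=CC[C@@H](OC)O[C@@]3(c3ccccc3)CCC2=O)c1` gives 3200 nM, which lies within the scatter of compound 3, while compound 1 `CO[C@@H]1CC=C2NN(c3ccc([N+](=O)[O-])cc3)C(=O)CC[C@]2(c2ccccc2)O1` gives 7300 nM, a higher number beyond the scatter. Compound 4 `CO[C@@H]1CC=C2N(c3cc(Cl)cc(Cl)c3)C(=O)C[C@]2(c2ccccc2)O1` differs from compound 3 by 3,5-dichlorophenyl in place of 4-methylphenyl on an amide-type nitrogen in a ring. Among the compounds with values here, the only measured step that also swaps the aryl group on that amide nitrogen is a 2.3-fold lower number from compound 1 to compound 2 (0.36 log units; beyond the scatter), though on a different core; it suggests a modest shift in this assay, and no step involving a dichlorophenyl group has been measured. A modest change is therefore expected, with direction uncertain, so compound 4 is estimated at 3000 nM (range 1200 nM to 8000 nM), corresponding to an expected step of a 1.2-fold lower number from compound 3 to compound 4 (0.07 log units; within the scatter).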

Compound 4, half-maximal inhibitory concentration: 9670 nM
Estimate against measurement, compound 4: 3.2-fold (0.51 log units) below; measured number above the stated range.
By their numbers in this assay, from the lowest: compounds 2 and 3 (each within the scatter of the next); then compounds 1 and 4 (each within the scatter of the next).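

On the amide-type nitrogen of the five-membered ring, 3,5-dichlorophenyl in place of 4-methylphenyl gives a 2.8-fold higher number from compound 3 to compound 4 (0.44 log units; beyond the scatter) in this assay. The number at this position therefore responds to the aryl group on this core too, not only on the core of compound 1, where the earlier swap gave a 2.3-fold lower number from compound 1 to compound 2 (0.36 log units; beyond the scatter). No measurement shown accounts for the rise.

Going by these compounds, it remains open whether the rise follows from the two chlorines or from the loss of the methyl. A phenyl ring with a single chlorine, or one carrying an amine, would help separate these.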